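A few compounds are considered here, and "the series" means these few. Any claim that something is new, unique, unknown or untested is made for them only; others in the source may bear on it.

Measured compounds

Compound 1 `Brc1cccc(Cc2nnc(Cn3nnc4ccccc43)o2)c1`: in an ADME assay on cells (Macrophage, Homo sapiens) for inhibition (a higher number here means that more compound is tolerated, a lower number that less compound is tolerated), compound 1 gives > 100000 nM, which is a limit of the assay and not a number.
Compound 2 `COc1cccc(Cc2nnc(Cn3nnc4ccccc43)o2)c1`: in this assay compound 2 gives > 100000 nM, again a limit of the assay.
Compound 3 `Brc1ccc(-c2nnc(Cn3nnc4ccccc43)o2)cc1`: in this assay compound 3 gives > 100000 nM, also a limit of the assay.

Notes

All three measured values sit at the same place, (the limit of > 100000 nM in this assay, at which 3 of the 3 values shown sit), so no value in this assay is a number here. The change from compound 1 to compound 2 is methoxy in place of bromo on an aromatic carbon; the corresponding step that the two limits leave unreadable from compound 1 to compound 2 cannot be read because both ends are limits. The difference between the cores of compound 1 and compound 3 is not broken down here.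

Compound 4 `COc1ccc(-c2nnc(Cn3nnc4ccccc43)o2)cc1` is unmeasured. It differs from compound 3 by methoxy in place of bromo on an aromatic carbon, the same kind of change as from compound 1 to compound 2, but the place is not identical: in compound 2 the methoxy sits meta to a large group, in compound 4 para to a large group.

Expectation: since compound 3 gives > 100000 nM as a limit, and the same kind of change in compound 2 also gives > 100000 nM as a limit, compound 4 is expected to show a step that the limit leaves unreadable from compound 3 to compound 4 in this assay, that is, most likely another limit rather than a number. The estimate for compound 4 in this assay is 200000 nM, expected to lie between 100000 nM and 600000 nM.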

Compound 4, half-maximal cytotoxic concentration: > 100000 nM
Compound 4 ended at the assay's limit; the forecaster's own chance of this, stated with the estimate: 90%; the middle value is on the limit's open side.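

The step from compound 3 to compound 4 cannot be read in this assay because both ends are limits of the assay and not numbers: the limit of > 100000 nM in this assay, at which 4 of the 4 values shown sit.

The compounds shown leave open at what concentration any of the four would reach the half-maximal cytotoxic read-out, and so whether methoxy in place of bromo shifts it at all.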